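Compound 2 loses one methoxy group

The source may hold more compounds than are shown below. What is called first, only, known or untested is meant among the compounds shown, and "the series" means these compounds.

Compound 1 `COC(=O)N1N=C(c2ccc(OC)cc2)CC1c1cc(OC)c(OC)c(OC)c1` gives 5000 nM
Compound 2 `COC(=O)N1N=C(c2cc(OC)c(OC)c(OC)c2)CC1c1cc(OC)c(OC)c(OC)c1` gives 14000 nM

In a functional assay on A2780 cells (Homo sapiens) for antiproliferative activity, read by MTT assay, with a stated time of 48 h (on this read-out higher numbers stand for weaker inhibition of growth and lower numbers for stronger inhibition of growth), compound 2 has the higher number of the two, and its gap to compound 1 lies beyond the scatter. Compound 3 `COC(=O)N1N=C(c2ccc(OC)c(OC)c2)CC1c1cc(OC)c(OC)c(OC)c1` carries hydrogen in place of methoxy on an aromatic carbon, ortho to a methoxy group hydrogen in place of methoxy on an aromatic carbon of compound 2. Within the data shown here, no measured pair shows this change alone. Compound 1 gives the lower number at 5000 nM, so a small fall is the expectation. The estimated 1.8-fold lower number from compound 2 to compound 3 (0.24 log units; within the scatter) points toward stronger inhibition of growth but stays within the scatter. For compound 3 the expected value is 8000 nM (estimated range 3500 nM to 18000 nM).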

Compound 3, concentration for 50% growth inhibition: 11400 nM
Compound 3: the middle estimate sits 1.4-fold (0.15 log units) below what was measured, within the range that was stated.
By their numbers in this assay, from the lowest: compound 1; then compounds 3 and 2 (each within the scatter of the next).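

In this assay, hydrogen in place of methoxy at this place gives a 1.2-fold lower number from compound 2 to compound 3 (0.09 log units; within the scatter), so this methoxy group, ortho to a methoxy group, does not separate compound 2 from compound 3. The clearer step lies elsewhere on the same ring: methoxy in place of hydrogen gives a 2.3-fold higher number from compound 1 to compound 3 (0.36 log units; beyond the scatter), a modest rise that locates the gap between compound 1 and compound 3 in one single change. No evidence here accounts for either step.

The compounds shown leave open how a hydroxyl group, a fluorine atom or an amine would read at this place. They also leave open whether either step holds when the methyl carbamate or the other trimethoxyphenyl ring is changed.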